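From Isopentyloxy to Hexylsulfanyl: What to Expect

The source may hold more compounds than are shown below. What is called first, only, known or untested is meant among the compounds shown, and "the series" means these compounds.

Compound 1 `CCOc1nc(C(C)(C)C)ccc1CNC(=O)C(C)c1ccc(NS(C)(=O)=O)c(F)c1`: 14.8 nM
Compound 2 `CC(C)CCOc1nc(C(C)(C)C)ccc1CNC(=O)C(C)c1ccc(NS(C)(=O)=O)c(F)c1`: 0.8 nM

Both compounds were tested in an assay on cells for antagonist activity at transient receptor potential cation channel subfamily V member 1 (Homo sapiens), read by FLIPR and calcium flux, with a stated time of 6 min; on this read-out lower numbers stand for stronger inhibition and higher numbers for weaker inhibition. For the measured compounds named here, compound 2 has the lowest of the two numbers, with compound 1 as its only neighbour. Going by the values given here, the single measured step, a 19-fold lower number from compound 1 to compound 2 (1.27 log units; beyond the scatter), was large and beyond the scatter; it involved isopropyl in place of hydrogen on a saturated chain carbon. Compound 3 `CCCCCCSc1nc(C(C)(C)C)ccc1CNC(=O)C(C)c1ccc(NS(C)(=O)=O)c(F)c1` differs from compound 2 by hexylsulfanyl in place of isopentyloxy on an aromatic carbon. Among the compounds with values here, that earlier step is the only one bearing on this change, and it favoured a longer chain. Since hexylsulfanyl is a chain of similar length, the step of a 1.3-fold higher number from compound 2 to compound 3 (0.10 log units; within the scatter) is expected to stay within the scatter. Compound 3 is estimated at 1 nM, between 0.3 nM and 4 nM.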

Compound 3, inhibition constant: 1.5 nM
Compound 3: middle estimate off by 1.5-fold (0.18 log units), on the low side, and the stated range covers the measured number.
By their numbers in this assay, from the lowest: compounds 2 and 3 (each within the scatter of the next); then compound 1.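

This position, next to the ring nitrogen, accepts a sulfur-linked straight chain as well as an oxygen-linked branched one: hexylsulfanyl in place of isopentyloxy gives a 1.9-fold higher number from compound 2 to compound 3 (0.27 log units; within the scatter) in this assay and stays level with the best compound. Against ethoxy, hexylsulfanyl gives a 9.9-fold lower number from compound 1 to compound 3 (0.99 log units; beyond the scatter) and so keeps a large part of the advantage of the longer group. Nothing measured here explains these numbers.

The step changes the linking atom and the chain together, so hexyloxy or isopentylsulfanyl would be needed to separate them. From the compounds shown here alone, how far chains longer than hexyl would be accepted also stays open.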